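Aryl swap on the shared core: fluorophenyl replaces dichlorophenyl

The source may report more compounds than this note shows. Statements on the series, on what has been measured and on what is new or still open speak of the compounds shown alone.

Compound 1 `O=c1oc2ccccc2c2nc3c(ccc4cc[nH]c43)c(-c3c(Cl)cccc3Cl)c12` carries a 2,6-dichlorophenyl group on the shared core. In a functional assay on B16-F10 cells (Mus musculus) for cytotoxicity (on this read-out lower numbers stand for stronger inhibition and higher numbers for weaker inhibition), compound 1 gives 70700 nM. Compound 2 `O=c1oc2ccccc2c2nc3c(ccc4cc[nH]c43)c(-c3ccc([N+](=O)[O-])cc3)c12` differs in one place, carrying a 4-nitrophenyl group in place of the 2,6-dichlorophenyl; in this assay compound 2 gives 70700 nM. The step of no change at the digits printed from compound 1 to compound 2 (within the scatter) is therefore flat, and compound 1 stands level with compound 2 on the numbers shown, with no other measured neighbour.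

Compound 3 `O=c1oc2ccccc2c2nc3c(ccc4cc[nH]c43)c(-c3ccc(F)cc3)c12` is the next member, not yet measured. Its change from compound 1 is 4-fluorophenyl in place of 2,6-dichlorophenyl on an aromatic carbon. Within the data shown here, the only step bearing on this change is the one from compound 1 to compound 2, which swapped the same aromatic group for a different one and left this assay unmoved within the scatter. Among the measured compounds shown here, nothing measured so far shows that the aromatic group at this position shifts cytotoxicity on these cells, so the step for compound 3 is expected to be none beyond the scatter, with the estimated step of no change at the digits printed from compound 1 to compound 3 (within the scatter). Compound 3 is thus expected to come in around 70700 nM, estimated between 30000 nM and 160000 nM.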

Compound 3, half-maximal inhibitory concentration: 70700 nM
For compound 3 middle estimate and measured number coincide at the digits printed; the measured number falls inside the stated range.
By their numbers in this assay, from the lowest: compounds 1, 2 and 3 (each within the scatter of the next).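

In this assay, the 4-fluorophenyl group is a second replacement for the 2,6-dichlorophenyl group at this position, opposite the ring nitrogen, and the step is no change at the digits printed from compound 1 to compound 3 (within the scatter). Among these compounds, the new compound also gives the first comparison between two groups substituted at the same place on the phenyl ring: fluoro in place of nitro gives no change at the digits printed from compound 2 to compound 3 (within the scatter). The flat reading therefore now covers a pair of replacements that share neither chlorine nor nitro, and it extends across compounds 1, 2 and 3 only, with none of the three going against it.

Going by these compounds, all three compounds keep a six-membered aromatic ring of carbon only at this position, so the effect of a different kind of group there, such as an amine, a carboxylic acid or a longer alkyl chain, remains open. Also open, on these data alone, is whether a change elsewhere on the shared core would move the read-out in this assay, since every step here lies at this one position. No accompanying measurement speaks to why these values stand level.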